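The compounds below may be only part of what the source reports. "The series", "measured", "known", "first", "only" and "open" are said of these compounds alone.

The three measured compounds share one core and differ only in the chain that carries their acid group. Compound 1, `CC(CCc1cccc(OCc2ccc3ccccc3n2)c1)Cc1nnn[nH]1`, carries a tetrazole on a branched chain; compound 2, `O=C(O)CC1CCCC1Cc1ccc(OCc2ccc3ccccc3n2)cc1`, and compound 3, `O=C(O)CC1(CCc2ccc(OCc3ccc4ccccc4n3)cc2)CCCC1`, each carry a carboxylic acid. In a functional assay (lung) for inhibition, with Cavia porcellus as the target (on this read-out lower numbers stand for stronger inhibition and higher numbers for weaker inhibition), compound 1 gives 45 nM. In this assay compound 2 gives 90 nM, and compound 3 gives 60 nM. Compound 1 thus holds the lowest of the three numbers, yet both of the others fall within the scatter of it, so no order among the three can be read from these values.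

Compound 4, `c1cc(CCCCc2nnn[nH]2)cc(OCc2ccc3ccccc3n2)c1`, is compound 1 with a single change: hydrogen in place of methyl on a saturated chain carbon bound to two saturated chain carbons. Within the data shown here, no measured pair in this set differs by such a change, so nothing here shows directly how this kind of step plays out. A methyl removed from a saturated chain carbon is a small alteration of the part that carries the tetrazole, and compound 1 at 45 nM already has the lowest number in the set. The step of a 1.3-fold higher number from compound 1 to compound 4 (0.12 log units; within the scatter) is therefore expected to be small, most likely not beyond the scatter, and if anything toward a slightly higher number. Compound 4 is estimated at 60 nM, with a range from 20 nM to 180 nM.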

Compound 4, half-maximal inhibitory concentration: 105 nM
Compound 4: the middle estimate sits 1.8-fold (0.24 log units) below what was measured; the measured number falls inside the stated range.
By their numbers in this assay, from the lowest: compounds 1, 3, 2 and 4 (each within the scatter of the next, the first and the last beyond it).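

Among these compounds, replacing methyl with hydrogen on a saturated chain carbon bound to two saturated chain carbons gives the first readable step at this position: in this assay the change amounts to a 2.3-fold higher number from compound 1 to compound 4 (0.37 log units; beyond the scatter), which is modest but lies beyond the scatter. The earlier compounds shown here could not show this, since no two of them differed in one place and their numbers all lay within the scatter of one another. The result shows that this one methyl on the chain carrying the tetrazole is not silent in this read-out, and that losing it moves the number toward weaker inhibition, although nothing available accounts for the shift.

The compounds shown leave open how this carbon would read with an ethyl, a hydroxyl or a fluorine in place of the methyl, and so whether the trend runs beyond this single pair. They also leave open whether the same step would have a similar size on a longer chain, or on a chain that ends in a carboxylic acid in place of the tetrazole.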